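The source may report more compounds than this note shows. Statements on the series, on what has been measured and on what is new or still open speak of the compounds shown alone.

Measured compounds:
Compound 1, `Cc1ccccc1-c1noc(-c2ccc(C3CCCCC3)cc2)n1`. In a functional assay on CHO cells with sphingosine 1-phosphate receptor 4 (Homo sapiens) as the target, read by GTPgammaS binding (a lower number here means that less compound is needed, a higher number that more compound is needed for the effect), compound 1 gives > 10000 nM, which is a limit of the assay and not a number.
Compound 2, `Cc1cc(CCC(=O)O)ccc1-c1noc(-c2ccc(OC(C)C)c(Cl)c2)n1`. In this assay compound 2 gives > 10000 nM, likewise only a limit.

Within the data shown here, compound 1 therefore has no number of its own in this assay; it sits at the limit, and the one other value shown sits at the same place (the limit of > 10000 nM in this assay, at which 2 of the 2 values shown sit). Among the measured compounds shown here, nothing in the measured set separates the two compounds, and no step between measured compounds is available.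

Compound 3, `Cc1cc(CCCCCC(=O)O)ccc1-c1noc(-c2ccc(C3CCCCC3)cc2)n1`, differs from compound 1 by 5-carboxypentyl in place of hydrogen on an aromatic carbon. Compound 2 also carries an acid-bearing chain and yet returns only a limit, so the measured values give no direction for this change. The step from compound 1 to compound 3 is nonetheless expected to run toward less compound being needed, an at least 3.3-fold lower number from compound 1 to compound 3 (0.52 log units; beyond the scatter), with a real chance that only a limit is reported again. Compound 3 is estimated at 3000 nM, with a range from 300 nM to 30000 nM.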

Compound 3, half-maximal effective concentration: > 10000 nM
Compound 3 ended at the assay's limit; the forecaster's own chance of this, stated with the estimate: 45%; middle value at least 3.3-fold (0.52 log units) away from the limit.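

Compound 1 and compound 3 both return only a limit in this assay, so no step can be read between them. All the values shown sit at the same place: the limit of > 10000 nM in this assay, at which 3 of the 3 values shown sit.

The compounds shown leave open whether any change to the core of compound 1 gives a measurable number rather than a limit.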